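The source may hold more compounds than are shown below. What is called first, only, known or untested is meant among the compounds shown, and "the series" means these compounds.

Measured so far in an assay on HEK293 cells for inhibition of N-acylethanolamine-hydrolyzing acid amidase (Rattus norvegicus), read by LC-MS, with a stated time of 30 min; on this read-out higher numbers stand for weaker inhibition and lower numbers for stronger inhibition:
compound 1, `Cc1ccccc1CCCCCCC(=O)N1CCCC1`: 68400 nM
compound 2, `O=C(CCc1ccc(-c2cccc(F)c2)cc1)N1CCCC1`: 1800 nM
compound 3, `COc1ccc(CCCCCCC(=O)N2CCCC2)cc1`: 35400 nM

Of the three numbers, compound 2 gives the lowest. The nearest number belongs to compound 3, and the gap between them lies beyond the scatter; compound 1 gives the furthest number, also beyond the scatter. Among the measured compounds shown here, no two of these measured compounds differ in a single place, so no measured step sets a scale for any one change on the shared core.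

Compound 4, `O=C(CCc1ccc(-c2ccsc2)cc1)N1CCCC1`, has not yet been measured in this assay. It differs from compound 2 in one place: thiophen-3-yl in place of 3-fluorophenyl on an aromatic carbon. For the measured compounds named here, with no measured step of comparable kind to lean on, the expectation rests on compound 2 alone, whose value is 1800 nM. The step from compound 2 to compound 4 is estimated at a 1.7-fold higher number from compound 2 to compound 4 (0.22 log units; within the scatter), a small shift toward a higher number that may well stay within the scatter. The estimate for compound 4 is 3000 nM, with a range from 1000 nM to 10000 nM.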

Compound 4, half-maximal inhibitory concentration: 2500 nM
The estimate for compound 4 lay 1.2-fold (0.08 log units) above the measured number; measured number inside the range.
By their numbers in this assay, from the lowest: compounds 2 and 4 (each within the scatter of the next); then compounds 3 and 1 (each within the scatter of the next).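

Among the compounds shown here, the step of a 1.4-fold higher number from compound 2 to compound 4 (0.14 log units; within the scatter) is the first single-place comparison and gives a scale in this assay for the aromatic carbon para to a group of 9 heavy atoms. At this position, thiophen-3-yl, a five-membered aromatic ring with 1 hetero atom, and 3-fluorophenyl, a six-membered aromatic ring of carbon only, cannot be told apart beyond the scatter. No supporting data bear on this result.

As far as these compounds go, whether this tolerance extends to other groups at the same position, such as a carboxylic acid, an amine or a pyridine ring, remains open. Compounds 1 and 3 each differ from compound 2 and compound 4 in more than one place, so the effect of chain length alone cannot be read.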